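A few compounds are considered here, and "the series" means these few. Any claim that something is new, unique, unknown or untested is made for them only; others in the source may bear on it.

Compound 1 `CCc1cc(C)c(C(=O)N=C(N)N)cc1S(C)(=O)=O` gives 4.8 nM in a functional assay for inhibition of sodium/hydrogen exchanger (Oryctolagus cuniculus); a lower number here means a stronger inhibitor, a higher number a weaker inhibitor. Compound 2 `CCCSc1cc(C)c(C(=O)N=C(N)N)cc1S(C)(=O)=O` gives 6.8 nM in this assay, and compound 3 `Cc1cc(SC(C)C)c(S(C)(=O)=O)cc1C(=O)N=C(N)N` gives 12 nM in this assay, sitting at the top of the three numbers, yet only a 2.5-fold higher number from compound 1 to compound 3 (0.40 log units; beyond the scatter) lies beyond the scatter, while a 1.8-fold higher number from compound 2 to compound 3 (0.25 log units; within the scatter). Compound 4 `Cc1cc(O)c(S(C)(=O)=O)cc1C(=O)N=C(N)N` has not yet been measured; its change from compound 3 is hydroxy in place of isopropylsulfanyl on an aromatic carbon. The measured steps cover only swaps among ethyl, propylsulfanyl and isopropylsulfanyl on the same aromatic carbon, where a 1.4-fold higher number from compound 1 to compound 2 (0.15 log units; within the scatter) and a 2.5-fold higher number from compound 1 to compound 3 (0.40 log units; beyond the scatter) stayed small. Among the compounds with values here, no measured step brings a hydroxy there, so compound 4 is expected to shift by a 1.7-fold higher number from compound 3 to compound 4 (0.22 log units; within the scatter) in this assay, toward a higher number. Compound 4 is estimated at 20 nM, with a range from 6 nM to 70 nM.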

Compound 4, half-maximal inhibitory concentration: 220 nM
The estimate for compound 4 lay 11-fold (1.04 log units) below the measured number; the measured number lies above the stated range.
By their numbers in this assay, from the lowest: compounds 1, 2 and 3 (each within the scatter of the next, the first and the last beyond it); then compound 4.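

Ethyl, propylsulfanyl and isopropylsulfanyl had differed only modestly at this aromatic carbon, but hydroxy shows that the position is far from indifferent to its substituent in this assay, with an 18-fold higher number from compound 3 to compound 4 (1.26 log units; beyond the scatter), a 32-fold higher number from compound 2 to compound 4 (1.51 log units; beyond the scatter) and a 46-fold higher number from compound 1 to compound 4 (1.66 log units; beyond the scatter). The change also brings a hydrogen-bond donor where isopropylsulfanyl has none and leaves a much smaller group, though nothing here separates these two differences or accounts for the loss. The compounds shown leave open whether methoxy or an amine on this carbon would behave like hydroxy or like the sulfur-linked chains.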